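Glycine transporter 1 inhibitors: chloro to fluoro step

The source may report more compounds than this note shows. Statements on the series, on what has been measured and on what is new or still open speak of the compounds shown alone.

Measured compounds:
Compound 1 `CN(CCC(Cc1ccc(C(F)(F)F)cc1)c1ccccc1)CC(=O)O` — 1000 nM
Compound 2 `CN(CCC(Oc1ccc(C(F)(F)F)cc1)c1ccc(Cl)cc1)CC(=O)O` — 100 nM

In an assay on CHO cells for inhibition of sodium- and chloride-dependent glycine transporter 1 (Homo sapiens) (a lower number here means a stronger inhibitor, a higher number a weaker inhibitor), compound 1 gives 1000 nM, while compound 2 gives 100 nM. Compound 2 therefore holds the lowest number of the two, and the gap to compound 1 lies beyond the scatter. Within the data shown here, compounds 1 and 2 differ in more than one place, so no single step connects them and the two values are taken only as they stand.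

Compound 3 `CN(CCC(Oc1ccc(C(F)(F)F)cc1)c1ccc(F)cc1)CC(=O)O` is not yet measured. It differs from compound 2 in one place: fluoro in place of chloro on an aromatic carbon. Among the measured compounds shown here, no measured pair in this set shows such a change, so there is no direct precedent to lean on. A small step is expected, most likely toward a somewhat higher number, not far beyond the scatter. For compound 3 the expected value in this assay is 200 nM, with a range from 70 nM to 600 nM, which is expected to read as a 2.0-fold higher number from compound 2 to compound 3 (0.30 log units; within the scatter).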

Compound 3, half-maximal inhibitory concentration: 251 nM
The estimate for compound 3 lay 1.3-fold (0.10 log units) below the measured number, within the range that was stated.
By their numbers in this assay, from the lowest: compound 2; then compound 3; then compound 1.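

In this assay, the series now has its first step that can be read at a single place: exchanging 4-chlorophenyl for 4-fluorophenyl gives (a 2.5-fold higher number from compound 2 to compound 3 (0.40 log units; beyond the scatter)). This position, on an aromatic carbon para to a large group, is therefore sensitive to which halogen it carries, and the chloro compound holds the lower number by a modest margin. Nothing shown gives a measured reason for this difference.

On these data alone, it remains open whether a bromo or a methoxy group at this position would give a number lower or higher than those of chloro and fluoro. Also open, as far as these compounds go, is whether the same exchange of chloro for fluoro gives a step of similar size when a methylene group replaces the ether oxygen of the shared core.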